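Benzyl in place of tert-butyl: compound 4 from compound 2

A few compounds are considered here, and "the series" means these few. Any claim that something is new, unique, unknown or untested is made for them only; others in the source may bear on it.

Compound 2 `CC(C)(C)Cc1cnc(CCc2ccc(-c3ccccc3C(=O)O)cc2)[nH]1` gives 6.3 nM in an in vitro functional assay on cells for agonist activity at Bombesin receptor subtype-3 (Mus musculus), read by luminescence and calcium flux (on this read-out lower numbers stand for an effect already at smaller amounts and higher numbers for an effect only at larger amounts of compound), the lowest of the three numbers measured in the series. Compound 1 `COc1ccccc1Cc1cnc(CCc2ccc(-c3ccccc3C(=O)O)cc2)[nH]1` gives 163 nM in this assay, and compound 3 `CCCCc1cnc(C(C)Cc2ccc(-c3ccccc3C(=O)O)cc2)[nH]1` gives 184 nM; both stand well above compound 2, with their gaps to it beyond the scatter.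

Among the compounds with values here, the one measured step at the same place is a 26-fold lower number from compound 1 to compound 2 (1.41 log units; beyond the scatter). Compound 4 `O=C(O)c1ccccc1-c1ccc(CCc2ncc(CCc3ccccc3)[nH]2)cc1` carries the change (benzyl in place of tert-butyl on a saturated chain carbon bound to an aromatic carbon). Here a group with an aromatic ring enters where tert-butyl stood; in compound 1 the group at this place also carried a ring, and compound 1 sits far above compound 2. Benzyl is not 2-methoxyphenyl, so the full reversal of that step need not follow, but a move back toward the number of compound 1 is the expectation. Compound 4 is therefore expected at 80 nM, with a range of 20 nM to 400 nM, which would mean an expected 13-fold higher number from compound 2 to compound 4 (1.10 log units; beyond the scatter).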

Compound 4, half-maximal effective concentration: 174 nM
Compound 4: middle estimate off by 2.2-fold (0.34 log units), on the low side; the measured number falls inside the stated range.
By their numbers in this assay, from the lowest: compound 2; then compounds 1, 4 and 3 (each within the scatter of the next).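

Benzyl on a saturated chain carbon bound to an aromatic carbon gives a 28-fold higher number from compound 2 to compound 4 (1.44 log units; beyond the scatter) and, against the 2-methoxyphenyl of compound 1, a 1.1-fold higher number from compound 1 to compound 4 (0.03 log units; within the scatter) at this position. Among compounds 1, 2 and 4, which differ only at this place, the low number therefore belongs to tert-butyl alone, and both groups carrying an aromatic ring give high numbers, with no compound among these three going against that pattern. The data hold no measurement that explains this difference.

Going by these compounds, whether the aromatic ring itself sets the higher number remains open, as does how cyclohexyl would stand at this place. On these data alone, how an amine or a carboxylic acid on the group at this place would affect the number is also open.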